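Substituting the amine nitrogen of compound 1

The compounds below may be only part of what the source reports. "The series", "measured", "known", "first", "only" and "open" are said of these compounds alone.

Compound 1 `COc1ccc(/C(=C(/CCN)c2ccccc2)c2ccccc2)cc1` is the reference of the set. Among the compounds with values here, in a functional assay on MDA-MB-231 cells (Homo sapiens) for cytotoxicity, read by MTT assay, with a stated time of 72 h (on this read-out lower numbers stand for stronger inhibition and higher numbers for weaker inhibition), compound 1 gives 11400 nM, the only number among the three values shown. The other two values are capped by the assay. Compound 2 `CCOC(=O)C(=O)NCC/C(=C(\c1ccccc1)c1ccc(OC)cc1)c1ccccc1` returns only a limit, > 50000 nM. Compound 3 `COc1ccc(/C(=C(/CCNC(=O)NCc2ccccc2)c2ccccc2)c2ccccc2)cc1` likewise returns only a limit, > 50000 nM. Each substitution on the amine nitrogen weakens the response: an at least 4.3-fold higher number from compound 1 to compound 2 (0.64 log units; beyond the scatter), and an at least 4.3-fold higher number from compound 1 to compound 3 (0.64 log units; beyond the scatter). The step that the two limits leave unreadable from compound 2 to compound 3 cannot be sized because the limit of > 50000 nM in this assay, at which 2 of the 3 values shown sit, caps both values. Compound 4 `COc1ccc(/C(=C(/CCNC(=O)C(=O)N2CCCCC2)c2ccccc2)c2ccccc2)cc1` is unmeasured; it differs from compound 1 by ((piperidin-1-yl)carbonyl)carbonyl in place of hydrogen on an amine nitrogen. Both measured steps on the same nitrogen bear on it, each at least modest and each ending at the limit, and compound 4 carries a comparable acyl group there. The expected outcome for compound 4 is accordingly a weaker number, a 4.4-fold higher number from compound 1 to compound 4 (0.64 log units; beyond the scatter), with a sizeable chance of another limit. The estimate for compound 4 is 50000 nM, within 15000 nM to 150000 nM.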

Compound 4, half-maximal inhibitory concentration: > 50000 nM
Compound 4 was reported as a limit (the forecaster's own chance of this, stated with the estimate: 60%); the middle value lies on the limit itself.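

In this assay, a further group on the amine nitrogen, ((piperidin-1-yl)carbonyl)carbonyl, gives an at least 4.3-fold higher number from compound 1 to compound 4 (0.64 log units; beyond the scatter), so all three substitutions shown at this position point the same way and none of them goes against it. Within the data shown here, this group brings a six-membered non-aromatic ring and 0 hydrogen-bond donors, yet the value of compound 4 is again a limit, which leaves compound 1, with its free amino group, as the only one of the four compounds with a number. The steps among compound 2, compound 3 and compound 4 cannot be read: the limit of > 50000 nM in this assay, at which 3 of the 4 values shown sit.

As far as these compounds go, how far these three compounds lie past the limit stays open. So does whether a methyl or acetyl group on this nitrogen, or a longer chain carrying the amine, would keep a readable number.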